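The source may hold more compounds than are shown below. What is called first, only, known or untested is meant among the compounds shown, and "the series" means these compounds.

Measured compounds:
compound 1, `CC(=O)OCC(CCn1cc(C#CCc2ccccc2)c(=O)n(C(=O)c2ccccc2)c1=O)COC(C)=O`: 29900 nM
compound 2, `CCCCCC#Cc1cn(CCC(COC(C)=O)COC(C)=O)c(=O)n(C(=O)c2ccccc2)c1=O`: 53700 nM
compound 3, `O=c1[nH]c(=O)n(CCC(CO)CO)cc1C#CCc1ccccc1`: 63800 nM

All numbers come from a functional assay on HeLa cells (Homo sapiens) for antiproliferative activity, read by MTT assay, with a stated time of 72 h; on this read-out higher numbers stand for weaker inhibition and lower numbers for stronger inhibition. Compound 3 stands at the high end of the three: its number and that of compound 2 lie within the scatter of each other, while compound 1 sits at a lower number, the gap to compound 3 beyond the scatter. Compound 3 is the only one of the three that carries no acyl groups on the diol and on the ring nitrogen.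

Compound 4, `CC(C)(C)C#Cc1cn(CCC(CO)CO)c(=O)[nH]c1=O`, is unmeasured. The change from compound 3 is tert-butyl in place of benzyl on a triple-bonded carbon. Going by the values given here, one measured step bears on it: a 1.8-fold higher number from compound 1 to compound 2 (0.25 log units; within the scatter), which also exchanged an aromatic group for a saturated alkyl group on the alkyne side chain, in a more acylated pair. That step stayed within the scatter, so no step beyond the scatter is expected here either; in this assay the expected step is a 1.1-fold higher number from compound 3 to compound 4 (0.04 log units; within the scatter). Compound 4 is therefore estimated at 70000 nM, with a range from 25000 nM to 190000 nM, resting on compound 3 at 63800 nM.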

Compound 4, half-maximal inhibitory concentration: > 100000 nM
Compound 4 ended at the assay's limit (the forecaster's own chance of this, stated with the estimate: 25%); middle value at least 1.4-fold (0.15 log units) from the limit.
By their numbers in this assay, from the lowest: compounds 1, 2 and 3 (each within the scatter of the next, the first and the last beyond it). At a limit, above all of these: compound 4.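

In this assay, compound 4 gives > 100000 nM, which is a limit of the assay and not a number. The exchange of benzyl for tert-butyl on this triple-bonded carbon gives an at least 1.5-fold higher number from compound 3 to compound 4 (0.19 log units; that floor lies within the scatter), a floor within the scatter that bounds the step from one side only, so it does not by itself separate the two compounds. Unlike the step from compound 1 to compound 2, this exchange was read on a core with no acyl groups on the diol and ring nitrogen, and it reaches the top of the read-out: the limit of > 100000 nM in this assay, at which 1 of the 4 values shown sits.

On these data alone, the true size of the step stays open, as does whether tert-butyl would give a readable number with acyl groups on the diol and ring nitrogen. Also open, as far as these compounds go, is how an amine or a longer chain on this triple-bonded carbon would read on the unacylated core.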